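Swapping the sulfonamide amine on a prostaglandin receptor ligand

The compounds below may be only part of what the source reports. "The series", "measured", "known", "first", "only" and "open" are said of these compounds alone.

Compound 1 `COCCN(C)S(=O)(=O)c1ccc(C)c(C#Cc2cc(Cl)ccc2OCC(=O)O)c1` gives 4.1 nM in an assay on CHO cells for displacement of a labelled ligand from prostaglandin D2 receptor 2 (Homo sapiens), read by scintillation counting; a higher number here means a weaker inhibitor, a lower number a stronger inhibitor.
Compound 2 `CN(c1cccc(C#Cc2cc(Cl)ccc2OCC(=O)O)c1)S(C)(=O)=O` gives 122 nM in this assay.

Compound 1 has the lower of the two numbers; compound 2 sits well beyond the scatter, at a much higher value. Compound 3 `CCN(CC)S(=O)(=O)c1ccc(C)c(C#Cc2cc(Cl)ccc2OCC(=O)O)c1` keeps the shared core of compound 1 and changes only the group on the sulfonyl sulfur: diethylamino in place of (2-methoxyethyl)(methyl)amino on a sulfonyl sulfur. For the measured compounds named here, no measured pair shows this exact change. Since compound 1 gives 4.1 nM and the change is small, the step of a 1.2-fold higher number from compound 1 to compound 3 (0.09 log units; within the scatter) is expected to stay within the scatter. For compound 3 the expected value in this assay is 5 nM, within 1.5 nM to 16 nM.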

Compound 3, inhibition constant: 3.4 nM
Compound 3: the middle estimate sits 1.5-fold (0.17 log units) above what was measured; measured number inside the range.
By their numbers in this assay, from the lowest: compounds 3 and 1 (each within the scatter of the next); then compound 2.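

On the sulfonyl sulfur, diethylamino serves as well as (2-methoxyethyl)(methyl)amino in this assay, with a 1.2-fold lower number from compound 1 to compound 3 (0.08 log units; within the scatter). The oxygen of the (2-methoxyethyl)(methyl)amino group, the hydrogen-bond acceptor counted there, is therefore not needed for a number this low. No evidence at hand explains why the two groups match. Still open, as far as these compounds go, is whether a ring amine such as morpholine or piperidine would keep the number this low on the sulfonyl sulfur. A plain amino group or longer alkyl chains on the nitrogen remain equally untested here.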